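Series notes: replacing the aminopyrazole with a dimethyloxazole

The compounds below may be only part of what the source reports. "The series", "measured", "known", "first", "only" and "open" are said of these compounds alone.

Measured in a functional assay on LoVo cells (Homo sapiens) for antiproliferative activity, read by MTT assay, with a stated time of 72 h; a higher number here means a weaker inhibitor, a lower number a stronger inhibitor:
- compound 1 `Cc1noc(C)c1-c1nn(Cc2ccc(C(=O)NC3CC(C)(C)N([O])C(C)(C)C3)cc2)c(=O)c2ccccc12`: 41200 nM
- compound 2 `Cc1noc(C)c1-c1nn(Cc2ccc(C(=O)NC3CCN(C)CC3)cc2)c(=O)c2ccccc12`: > 100000 nM (a limit of the assay)
- compound 3 `Cn1cc(Nc2nn(Cc3ccc(C(=O)NC4CCCCC4)cc3)c(=O)c3ccccc23)cn1`: 5300 nM

Compound 3, at 5300 nM, has the lower of the two actual numbers. Compound 1, at 41200 nM, lies higher, by a gap beyond the scatter. Compound 2 gives > 100000 nM, which is a limit and not a number.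

Compound 4 `Cc1noc(C)c1-c1nn(Cc2ccc(C(=O)NC3CCCCC3)cc2)c(=O)c2ccccc12` keeps the amide side of compound 3 and changes one group on an aromatic carbon: 3,5-dimethyl-1,2-oxazol-4-yl in place of (1-methyl-1H-pyrazol-4-yl)amino on an aromatic carbon. For the measured compounds named here, no measured step makes this exchange. Going by the values given here, the only measured step, an at least 2.4-fold higher number from compound 1 to compound 2 (0.38 log units; beyond the scatter), changes the group on an amide-type nitrogen while 3,5-dimethyl-1,2-oxazol-4-yl stays in place, so it bears only indirectly. Compound 1 and compound 2 both carry the entering group and both sit higher than compound 3, but they also differ from it on the amide side, so that gap cannot be assigned to this exchange alone.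

A moderately higher number in this assay is therefore expected, resting on compound 1 at 41200 nM, though no change beyond the scatter remains possible. The estimated change is a 2.3-fold higher number from compound 3 to compound 4 (0.35 log units; beyond the scatter). For compound 4 the estimate is 12000 nM, with an expected range from 3000 nM to 45000 nM.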

Compound 4, half-maximal inhibitory concentration: 82200 nM
Compound 4: the middle estimate sits 6.9-fold (0.84 log units) below what was measured; measured number above the stated range.
By their numbers in this assay, from the lowest: compound 3; then compounds 1 and 4 (each within the scatter of the next). At a limit, above all of these: compound 2.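

In this assay, for the compounds shown here, with the cyclohexyl amide held fixed, exchanging the group on this aromatic carbon, next to the ring nitrogen, gives a 16-fold higher number from compound 3 to compound 4 (1.19 log units; beyond the scatter): the first direct reading of this change, and a large one. On the amide side, with 3,5-dimethyl-1,2-oxazol-4-yl in place, cyclohexyl gives a 2.0-fold higher number from compound 1 to compound 4 (0.30 log units; within the scatter), so these two amide groups are not told apart here. Cyclohexyl in place of 1-methylpiperidin-4-yl gives an at least 1.2-fold lower number from compound 2 to compound 4 (0.08 log units; that floor lies within the scatter), and this step cannot be read. Going by these compounds alone, the exchange at the aromatic carbon is therefore the only step beyond the scatter that involves compound 4. Compound 2 stands at a limit: the limit of > 100000 nM in this assay, at which 1 of the 4 values shown sits.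

The exchange removes the amino nitrogen and replaces the ring in one move, and the compounds shown do not separate these two parts; a 1-methyl-1H-pyrazol-4-yl joined directly to the core, or a 3,5-dimethyl-1,2-oxazol-4-yl joined through an amino nitrogen, would divide the step. From the compounds shown here alone, the size of the step is also read on the cyclohexyl amide alone, so it remains open whether it holds with another amide group, such as a 1-methylpiperidin-4-yl amide carrying the aminopyrazole.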